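This account rests on a few compounds, and the source may have more. Where it says the series, first, only, none or still open, it means among the compounds named here.

Compound 1 `COCn1c(CC(COCc2ccccc2)COCc2ccccc2)c(C)c(=O)[nH]c1=O` gives 55900 nM in a functional assay on MIA PaCa-2 cells (Homo sapiens) for antiproliferative activity, read by MTT assay, with a stated time of 72 h; a higher number here means a weaker inhibitor, a lower number a stronger inhibitor. Compound 2 `Cc1c(CC(O)COCc2ccccc2)n(COCC[Si](C)(C)C)c(=O)[nH]c1=O` is reported in this assay only as a limit, > 100000 nM, which is the limit of > 100000 nM in this assay, at which 1 of the 2 values shown sits, and not a measured number. Compound 3 `COCn1c(CC(O)COCc2ccccc2)c(C)c(=O)[nH]c1=O` is the next compound in line for this assay; it differs from compound 2 by a hydrogen atom in place of a group of 5 heavy atoms (4 carbon, 1 silicon; no ring), on a saturated chain carbon bound to an oxygen on a saturated carbon. For the measured compounds named here, with no measured step of this kind to lean on, the change is expected to move potency little, if at all, beyond the usual scatter. Compound 3 is therefore estimated at 120000 nM, between 40000 nM and 400000 nM, a step that the limit leaves unreadable from compound 2 to compound 3 that is expected rather than known.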

Compound 3, half-maximal inhibitory concentration: > 100000 nM
Compound 3 ended at the assay's limit; the forecaster's own chance of this, stated with the estimate: 60%; the middle value does not contradict the limit.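

Replacing (benzyloxy)methyl with hydroxy, on a saturated chain carbon bound to two saturated chain carbons, gives an at least 1.7-fold higher number from compound 1 to compound 3 (0.25 log units; that floor lies within the scatter). On these data alone, compound 3 is reported only as a limit, so this swap shows no gain in potency, and the true size of the step stays unknown. The step from compound 2 to compound 3 cannot be read, because both values are limits and not numbers: the limit of > 100000 nM in this assay, at which 2 of the 3 values shown sit.

The compounds shown leave open how an amine, a carboxylic acid or a longer chain on that carbon would read. They also leave open whether any such group would give a value clear of the limit.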